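The source may hold more compounds than are shown below. What is called first, only, known or untested is meant among the compounds shown, and "the series" means these compounds.

Of the compounds shown here, two have so far been tested in a functional assay on C6 cells (Rattus norvegicus) for cytotoxicity, read by MTT assay, with a stated time of 24 h, tested at 25 ug/mL; a lower number here means a stronger effect, a higher number a weaker effect of the compound at the concentration tested. Compound 1 `O=C(CSc1nnnn1-c1ccccc1)N/N=c1/scc(-c2ccc(Br)cc2)n1-c1ccccc1` gives 47.9% in this assay, the lower of the two numbers and thus the stronger effect. Compound 2 `Cc1ccc(-c2cs/c(=N/NC(=O)CSc3nncn3C)n2-c2ccccc2)cc1` gives 70.7%, a number that lies higher than that of compound 1 by more than the usual scatter. Compound 3 `O=C(CSc1nnnn1-c1ccccc1)N/N=c1/scc(-c2ccc(F)cc2)n1-c1ccccc1` has not yet been measured. It differs from compound 1 in a single place: fluoro in place of bromo on an aromatic carbon. Going by the values given here, no measured pair shows what this exchange does on the shared core, so there is no direct precedent to lean on. The expected step in this assay, a number 7.1 percentage points higher from compound 1 to compound 3 (within the scatter), is modest and tilted towards a somewhat higher number, though a step within the scatter would not be surprising. Compound 3 is therefore estimated to reach about 55%, within a range from 40% to 72%.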

Compound 3, a percentage reported as activity, at one concentration (the size of the read-out at that concentration, not a potency): 49.3%
Compound 3: middle estimate off by 5.7 percentage points, on the high side, and the stated range covers the measured number.
By their numbers in this assay, from the lowest: compounds 1 and 3 (each within the scatter of the next); then compound 2.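

In this assay, fluoro in place of bromo on an aromatic carbon gives a number 1.4 percentage points higher from compound 1 to compound 3 (within the scatter), so compound 1 and compound 3 cannot be told apart at the concentration tested. Going by these compounds alone, this is the first direct reading of a change at this position, as compound 1 and compound 2 differ in more than one place and could not isolate it. For these two compounds, the exchange between these two halogens leaves the read-out within its usual scatter, and no supporting data bear on why that is so.

On these data alone, it remains open whether a group other than a halogen at this position, such as an amine, a carboxylic acid or a longer alkyl chain, would move the number beyond the scatter. As far as these compounds go, it also remains open whether the same exchange would read alike on a different core or at other concentrations.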